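Swapping an Aromatic Ring for a Saturated One

This account rests on a few compounds, and the source may have more. Where it says the series, first, only, none or still open, it means among the compounds named here.

Measured compounds:
- compound 1, `CNC(=O)c1cc(C(=O)NC2CCC2)cn(Cc2ccccc2)c1=O`, gives 3.8 in a physicochemical assay for lipophilicity, at pH 7.4; on this read-out higher numbers stand for higher lipophilicity and lower numbers for lower lipophilicity.
- compound 2, `CNC(=O)c1cc(C(=O)NCC(C)C)cn(Cc2ccccc2)c1=O`, gives 4.3 in this assay.
- compound 3, `CNC(=O)c1cc(C(=O)NC2CC2)cn(Cc2cccc3[nH]ccc23)c1=O`, gives 2.9 in this assay.

Compound 3 stands lowest of the three in this assay. Its nearest neighbour is compound 1, which lies higher by a margin beyond the scatter, and compound 2 lies further above it still. Among the measured compounds shown here, the only step between measured compounds that differ in a single place is a number 0.50 log units higher from compound 1 to compound 2 (beyond the scatter); that change sits on an amide-type nitrogen, far from the ring altered here, so it offers no direct guide.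

Compound 4, `CNC(=O)c1cc(C(=O)NC2CC2)cn(Cc2cccc3c2CCN3)c1=O`, is the compound still to be measured. Compared with compound 3 it changes in one place: 2,3-dihydro-1H-indol-4-yl in place of 1H-indol-4-yl on a saturated chain carbon bound to an aromatic nitrogen. The group that leaves and the group that enters have the same number of heavy atoms; what changes is that the five-membered ring is no longer aromatic and one hydrogen-bond acceptor is added. For the measured compounds named here, with no measured pair showing a swap of this kind, the expectation rests on the change alone, and a small downward step of a number 0.30 log units lower from compound 3 to compound 4 (within the scatter) is expected, possibly within the scatter. Compound 4 is therefore estimated at 2.6, in the range 2.1 to 3.1.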

Compound 4, distribution coefficient: 2.1
The estimate for compound 4 lay 0.50 log units above the measured number; the measured number falls inside the stated range.
By their numbers in this assay, from the lowest: compound 4; then compound 3; then compound 1; then compound 2.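

The swap of the aromatic five-membered ring for a non-aromatic one, on a saturated chain carbon bound to an aromatic nitrogen, gives a number 0.80 log units lower from compound 3 to compound 4 (beyond the scatter) in this assay. Among the compounds shown here, this is the first read-out of a change at this place, since the only earlier step sat on an amide-type nitrogen, and it shows that the number responds here even though the group that leaves and the group that enters have the same heavy-atom count and the same hydrogen-bond donor count. The only differences counted between the two groups are the loss of aromaticity in that ring and the added hydrogen-bond acceptor, and nothing available explains how either relates to the size of this step.

A single pair cannot separate those two differences, nor show whether the same swap would give a similar step with the cyclobutyl or isobutyl group on the amide-type nitrogen. On these data alone, it also remains open how the number would respond if 2,3-dihydro-1H-indol-4-yl gave way at this place to a group of a different kind, such as an open-chain amine or a carboxylic acid.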